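The source may hold more compounds than are shown below. What is called first, only, known or untested is meant among the compounds shown, and "the series" means these compounds.

Three compounds have been measured so far:
compound 1, `CCN(CC)C(=S)SCC1=CCOC1=O`, which gives 121000 nM in a functional assay on MCF7 cells (Homo sapiens) for antiproliferative activity, read by MTT assay, with a stated time of 72 h; a lower number here means a stronger inhibitor, a higher number a weaker inhibitor;
compound 2, `Cc1ccc(NC(=S)SCC2=CCOC2=O)cc1`, which gives 97400 nM in this assay;
compound 3, `O=C1OCC=C1CSC(=S)NC1CCCCC1`, which gives 180000 nM in this assay.

All three share the same core, seen in compound 1, and differ only in the group attached to the thiocarbonyl carbon. Compound 1 gives the middle number of the three, but the numbers of compound 2 and compound 3 both lie within the usual scatter of repeated measurements, so no order among the three can be claimed; all are weak inhibitors.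

Compound 4, `CC(C)NC(=S)SCC1=CCOC1=O`, has not yet been measured. It differs from compound 1 by isopropylamino in place of diethylamino on a thiocarbonyl carbon. Within the data shown here, no two measured compounds differ in exactly one place, so no measured step shows how such a change acts here. The measured compounds, with and without a hydrogen-bond donor on that nitrogen, all sit within the scatter of one another, so in this assay no step beyond the scatter is expected in either direction. Compound 4 is therefore estimated to give about 130000 nM, within a range of 60000 nM to 280000 nM. The step this estimate implies, a 1.1-fold higher number from compound 1 to compound 4 (0.03 log units; within the scatter), is expected to stay inside the scatter.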

Compound 4, half-maximal inhibitory concentration: 134000 nM
Compound 4: the middle estimate sits 1.0-fold (0.01 log units) below what was measured; measured number inside the range.
By their numbers in this assay, from the lowest: compounds 2, 1, 4 and 3 (each within the scatter of the next).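

This first measured single change on the thiocarbonyl carbon puts isopropylamino, with 4 heavy atoms and 1 hydrogen-bond donor, in place of diethylamino, with 5 heavy atoms and 0 hydrogen-bond donors, and in this assay it gives a 1.1-fold higher number from compound 1 to compound 4 (0.04 log units; within the scatter). In this one pair, a change in both the group's heavy-atom count and its hydrogen-bond donor count leaves the result within the usual scatter of repeated measurements, so the step shows no gain or loss of antiproliferative activity. No further information bears on this result.

From the compounds shown here alone, it remains open whether a group of a different kind on the thiocarbonyl carbon, such as a longer chain ending in a carboxylic acid or an amine, would give a step beyond the scatter. All the compounds shown keep the shared core unchanged, so they also leave open how a change to the core itself would act in this assay.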